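The compounds below may be only part of what the source reports. "The series", "measured", "known", "first", "only" and "open" are said of these compounds alone.

In a functional assay on MDA-MB-435 cells (Homo sapiens) for cytotoxicity, read by MTT assay, with a stated time of 72 h (a higher number here means a weaker inhibitor, a lower number a stronger inhibitor), compound 1 `N[C@H]1CC[C@H](Nc2c(C(=O)NCc3ccco3)nc(Br)c3cccnc23)CC1` gives > 10000 nM, which is a limit of the assay and not a number. Among the compounds with values here, compound 2 `COc1ccc(CNC(=O)c2nc(Br)c3cccnc3c2N[C@H]2CC[C@H](N)CC2)cc1` gives 5000 nM, the only true number so far. Compound 3 `CN(C)c1ccc(CNC(=O)c2nc(Br)c3cccnc3c2N[C@H]2CC[C@H](N)CC2)cc1` has dimethylamino in place of methoxy on an aromatic carbon, para to a large group: dimethylamino in place of methoxy on an aromatic carbon. Within the data shown here, only one measured step bears on this change, and only loosely. That step, an at least 2.0-fold lower number from compound 1 to compound 2 (0.30 log units; that floor lies within the scatter), swaps furan-2-yl for 4-methoxyphenyl, so it touches the same arm of the molecule, but its size is only a floor that lies within the scatter. Among the measured compounds shown here, nothing measured so far tests the group now being exchanged, so no clear direction can be expected. The expected 1.3-fold lower number from compound 2 to compound 3 (0.10 log units; within the scatter) stays within the scatter. Compound 3 is estimated at 4000 nM, with an expected range of 1500 nM to 10000 nM.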

Compound 3, half-maximal inhibitory concentration: 4000 nM
The estimate for compound 3 equals the measured number at the digits printed, and the stated range covers the measured number.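

In this assay, dimethylamino in place of methoxy, on an aromatic carbon para to a large group, gives a 1.3-fold lower number from compound 2 to compound 3 (0.10 log units; within the scatter), so the two groups cannot be told apart at this position. Within the data shown here, with 4-(dimethylamino)phenyl in place of furan-2-yl, the record shows an at least 2.5-fold lower number from compound 1 to compound 3 (0.39 log units; beyond the scatter), the first step on this arm of the molecule that is printed as beyond the scatter, although its size is still only a floor. That floor comes from compound 1, whose value is a limit of the assay and not a number: the limit of > 10000 nM in this assay, at which 1 of the 3 values shown sits.

Going by these compounds, whether a different group on the same aromatic carbon, such as a carboxylic acid or a nitrile, would move the number beyond the scatter remains open. On these data alone, the true size of the step away from furan-2-yl also remains open.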